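The source may hold more compounds than are shown below. What is called first, only, known or untested is meant among the compounds shown, and "the series" means these compounds.

Compound 1, `CN(C)CCCCN(C(=O)O)c1ccc(Cn2nc(-c3ccc(F)cc3)c3ccccc3c2=O)cc1`: 19000 nM
Compound 2, `CN(C)CCCCOC(=O)Nc1ccc(Cn2nc(-c3cncnc3)c3ccccc3c2=O)cc1`: 65300 nM

Of the compounds shown here, two have been tested in an ADME assay on Huh-7 cells (Homo sapiens) for cytotoxicity, read by MTT assay, with a stated time of 48 h; a higher number here means that more compound is tolerated, a lower number that less compound is tolerated. In this assay compound 1 gives 19000 nM, and compound 2 gives 65300 nM. Compound 2 thus stands highest of the two numbers shown, meaning more of it is tolerated by the cells; compound 1 stands lower, and the gap between the two lies beyond the usual scatter of repeat measurements. Among the measured compounds shown here, no pair of compounds differing in a single place has been measured yet, so no single step has a number.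

Compound 3, `CN(C)CCCCOC(=O)Nc1ccc(Cn2nc(-c3cccnc3)c3ccccc3c2=O)cc1`, has not been measured. It differs from compound 2 in one place: pyridin-3-yl in place of pyrimidin-5-yl on an aromatic carbon. For the measured compounds named here, both groups are flat six-membered aromatic rings of the same size, and only one ring nitrogen is exchanged for a carbon. With nothing measured yet on this change, the expectation is a step of a 1.3-fold lower number from compound 2 to compound 3 (0.12 log units; within the scatter) of no consequence, not beyond the scatter. Compound 3 is therefore estimated at 50000 nM, within a range from 20000 nM to 120000 nM.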

Compound 3, half-maximal cytotoxic concentration: 68000 nM
Compound 3: the middle estimate sits 1.4-fold (0.13 log units) below what was measured; the measured number falls inside the stated range.
By their numbers in this assay, from the lowest: compound 1; then compounds 2 and 3 (each within the scatter of the next).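

In this assay, among the compounds shown here, this is the first change at this position that can be read on its own, and the step is a 1.0-fold higher number from compound 2 to compound 3 (0.02 log units; within the scatter). Taking one ring nitrogen out of the six-membered aromatic ring on this aromatic carbon, and so going from 2 hydrogen-bond acceptors to 1, therefore leaves the number within the usual scatter of repeat measurements. No measurement at hand bears on why the two groups behave alike here.

The compounds shown cover only pyrimidin-5-yl and pyridin-3-yl in a single direct comparison, so it remains open whether the number would also stay put with a ring holding no nitrogen, such as a plain phenyl group, or with a non-ring group, such as an amine or a carboxylic acid, on the same carbon. Compound 1 differs from the other two in more than one place, so it cannot show what its own group at this position contributes, and this single step cannot say whether the same exchange would matter elsewhere on the shared core.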